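Methoxy on the pyridinyl amine: expectation for compound 3

The compounds below may be only part of what the source reports. "The series", "measured", "known", "first", "only" and "open" are said of these compounds alone.

Of the compounds shown here, two have been measured in an ADME assay on microsomes from liver (Rattus norvegicus) for metabolic stability, read by LC-MS, with a stated time of 30 min, tested at 0.1 uM; a lower number here means that less of the compound is left, a higher number that more of the compound is left. Compound 1 `FC(F)(F)c1cccc(-c2nc3cnc(Nc4ccccn4)cc3[nH]2)c1` gives 45% in this assay. Compound 2 `FC(F)(F)Oc1ccc(-c2nc3cnc(Nc4ccccn4)cc3[nH]2)cc1` gives 61% in this assay, which is beyond the scatter above the value of compound 1; compound 1 thus stands lowest of the two measured values. Within the data shown here, no pair of measured compounds differs in one place only, so these two values show only that more of compound 2 than of compound 1 remains.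

Compound 3 `COc1cccc(Nc2cc3[nH]c(-c4cccc(C(F)(F)F)c4)nc3cn2)n1` is not yet measured in this assay. It differs from compound 1 in one place: methoxy in place of hydrogen on an aromatic carbon, which turns the pyridin-2-yl into 6-methoxypyridin-2-yl. Among the measured compounds shown here, no measured pair carries this change, so the size of the step cannot be read from the data. The expected step of a number 7 percentage points lower from compound 1 to compound 3 (within the scatter) is small, if anything downward, and not beyond the scatter. Compound 3 is estimated at 38% in this assay, within a range from 20% to 58%.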

Compound 3, percent of the compound remaining: 49%
The estimate for compound 3 lay 11 percentage points below the measured number; the measured number falls inside the stated range.
By their numbers in this assay, from the lowest: compounds 1 and 3 (each within the scatter of the next); then compound 2.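

In this assay, among these compounds, the change from pyridin-2-yl to 6-methoxypyridin-2-yl gives a number 4 percentage points higher from compound 1 to compound 3 (within the scatter), the first step that can be read at a single place. This position, an aromatic carbon next to the ring nitrogen, therefore carries a methoxy group in place of hydrogen with no step beyond the scatter, so compound 1 and compound 3 cannot be told apart in this read-out. The data offer no independent measurement that could explain this result.

The compounds shown leave open whether another group on this carbon, such as an amine, a carboxylic acid or a longer chain like ethoxy, would give a step beyond the scatter. Among the compounds shown here, also open is whether methoxy at this place gives a similar step on the core of compound 2, as the only reading of this change comes from the background of compound 1, and a single step cannot show how it carries over to another compound.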